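Swapping the Benzyl Halogen on a Shared Acylurea Core

This account rests on a few compounds, and the source may have more. Where it says the series, first, only, none or still open, it means among the compounds named here.

Of the compounds shown here, two built on one shared core have been measured in a functional assay on MNK45 cells (Homo sapiens) for inhibition, read by MTT assay, with a stated time of 48 h; on this read-out higher numbers stand for weaker inhibition and lower numbers for stronger inhibition. Compound 1 `Cc1ccc(NC(=O)NC(=O)c2ccc(OCc3cccc(C(F)(F)F)c3)cc2)cc1-c1nc2ccccc2[nH]1` gives 9600 nM. Compound 2 `Cc1ccc(NC(=O)NC(=O)c2ccc(OCc3cccc(F)c3)cc2)cc1-c1nc2ccccc2[nH]1` gives 53000 nM in this assay, the higher of the two numbers and thus the weaker inhibitor of the pair. Within the data shown here, the single measured step between them, a 5.5-fold higher number from compound 1 to compound 2 (0.74 log units; beyond the scatter), lies beyond the scatter and runs toward weaker inhibition.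

Compound 3 `Cc1ccc(NC(=O)NC(=O)c2ccc(OCc3ccccc3Cl)cc2)cc1-c1nc2ccccc2[nH]1` differs from compound 2 in one place: 2-chlorophenyl in place of 3-fluorophenyl on a saturated chain carbon bound to an oxygen on an aromatic ring. Among the measured compounds shown here, no measured step covers this exact exchange. For the measured compounds named here, the only step that touches the same ring, a 5.5-fold higher number from compound 1 to compound 2 (0.74 log units; beyond the scatter), was modest in size, so a change of comparable size is plausible here, although its direction is not fixed by the data. On balance the number for compound 3 is expected to fall somewhat below that of compound 2, which would mean an estimated step of a 2.1-fold lower number from compound 2 to compound 3 (0.33 log units; beyond the scatter). The estimate for compound 3 in this assay is 25000 nM, with an expected range from 8000 nM to 80000 nM.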

Compound 3, half-maximal inhibitory concentration: 21500 nM
Estimate against measurement, compound 3: 1.2-fold (0.07 log units) above; low and high end bracket the measured number.
By their numbers in this assay, from the lowest: compound 1; then compound 3; then compound 2.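

In this assay, among these compounds, the exchange of 3-fluorophenyl for 2-chlorophenyl on the saturated chain carbon bound to an oxygen on an aromatic ring gives a 2.5-fold lower number from compound 2 to compound 3 (0.39 log units; beyond the scatter), which shows that this position can also move toward stronger inhibition, whereas the one earlier step ran only toward weaker inhibition. Compared with the 3-(trifluoromethyl)phenyl group, the 2-chlorophenyl group gives a 2.2-fold higher number from compound 1 to compound 3 (0.35 log units; beyond the scatter), so it does not recover the full number of compound 1 and places compound 3 between the other two, with both new steps beyond the scatter. Nothing available accounts for the direction or size of either step.

The names of the groups show that the halogen and its ring position change together from compound 2 to compound 3, so the compounds shown leave open how much of that step belongs to each. Also open, from the compounds shown here alone, is where a plain phenyl ring, a methoxy-bearing phenyl ring or a pyridine ring on the same chain carbon would fall relative to these three compounds.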